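The compounds below may be only part of what the source reports. "The series", "measured", "known", "first", "only" and "open" are said of these compounds alone.

Two compounds share a core in which an aminoquinazoline-like fragment is joined through a benzylic linker to a urea, and they differ only in the aryl group on the far urea nitrogen. Compound 1, `CC(C)(C)c1ccc(NC(=O)Nc2cccc(CNc3ncnc4ccccc34)c2)cc1`, gives 7470 nM in a functional assay on MGC-803 cells (Homo sapiens) for antiproliferative activity, read by MTT assay; on this read-out lower numbers stand for stronger inhibition and higher numbers for weaker inhibition. Compound 2, `O=C(Nc1cccc(CNc2ncnc3ccccc23)c1)Nc1ccccc1F`, gives 33400 nM in this assay. Among the measured compounds shown here, the one step between them, a 4.5-fold higher number from compound 1 to compound 2 (0.65 log units; beyond the scatter), is the only step measured so far, and it places compound 2 at the highest of the two numbers, with compound 1 as its only neighbour.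

Compound 3, `O=C(Nc1cccc(Cl)c1)Nc1cccc(CNc2ncnc3ccccc23)c1`, follows the change (3-chlorophenyl in place of 2-fluorophenyl on an amide-type nitrogen). For the measured compounds named here, no measured step swaps one halogenated phenyl for another on this nitrogen, so the step from compound 1 to compound 2 bears on it only indirectly: it shows that the aryl group on this nitrogen can move the number by a modest amount, and that a small halogenated phenyl sat at the weaker end of the two. From that, the expected step of a 1.9-fold lower number from compound 2 to compound 3 (0.27 log units; within the scatter) is estimated as a small move toward a lower number, not clearly beyond the scatter. Compound 3 is therefore expected to give about 18000 nM in this assay, within a range from 6000 nM to 50000 nM.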

Compound 3, half-maximal inhibitory concentration: 19200 nM
Compound 3: middle estimate off by 1.1-fold (0.03 log units), on the low side; the range from low to high includes it.
By their numbers in this assay, from the lowest: compound 1; then compounds 3 and 2 (each within the scatter of the next).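

In this assay, exchanging 2-fluorophenyl for 3-chlorophenyl on the amide-type nitrogen gives a 1.7-fold lower number from compound 2 to compound 3 (0.24 log units; within the scatter), so this swap of one halogenated phenyl for another does not separate the two compounds. Replacing the 4-(tert-butyl)phenyl group with 3-chlorophenyl gives a 2.6-fold higher number from compound 1 to compound 3 (0.41 log units; beyond the scatter), which means that a second halogenated phenyl now stands apart from the tert-butyl compound, and that among these three compounds compound 1 gives the strongest inhibition, with neither of the others going against that order. Nothing available explains these differences.

The step between compound 2 and compound 3 changes the halogen and its place on the ring together, so the compounds shown cannot tell whether either change alone would move the number in this assay. They also leave open how the read-out would respond to an unsubstituted phenyl, or to a phenyl carrying an amine, a carboxylic acid or a longer alkyl chain, on this nitrogen.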